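Working notes: ring swap on the shared core, compound 4

The source may report more compounds than this note shows. Statements on the series, on what has been measured and on what is new or still open speak of the compounds shown alone.

Measured so far in a functional assay on SK-BR-3 cells (Homo sapiens) for cytotoxicity, read by MTT assay, with a stated time of 72 h; on this read-out higher numbers stand for weaker inhibition and lower numbers for stronger inhibition:
compound 1 `N[C@H]1CC[C@H](Nc2c(C(=O)NCc3ccc(F)cc3)nc(N3CCCCC3)c3cccnc23)CC1`: > 10000 nM
compound 2 `COC(=O)c1nc(Br)c2cccnc2c1N[C@H]1CC[C@H](N)CC1`: "not determined" (no result reported)
compound 3 `N[C@H]1CC[C@H](Nc2c(C(=O)Nc3ccccc3)nc(Br)c3cccnc23)CC1`: 2000 nM

Compound 1 stands at a limit of the assay, not at a number; its entry is the limit of > 10000 nM in this assay, at which 1 of the 3 values shown sits. Compound 2 has no result in this assay. Among the three, only compound 3 carries a single value, 2000 nM in this assay. Among the compounds with values here, no pair of measured compounds differs in one place alone, so no measured step exists.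

The unmeasured compound is compound 4 `N[C@H]1CC[C@H](Nc2c(C(=O)NCc3ccc(F)cc3)nc(N3CCCCS3(=O)=O)c3cccnc23)CC1`. It differs from compound 1 by a group of 8 heavy atoms (4 carbon, 1 nitrogen, 2 oxygen, 1 sulfur; one six-membered non-aromatic ring with 2 hetero atoms) in place of a group of 6 heavy atoms (5 carbon, 1 nitrogen; one six-membered non-aromatic ring with 1 hetero atom), on an aromatic carbon. The change sits on the shared core of compound 1, where the piperidin-1-yl group previously stood.

With compound 1 known only as a limit, there is no measured anchor for the size of such a swap. The expectation is that the step from compound 1 to compound 4 is none beyond the scatter, that is a step that the limit leaves unreadable from compound 1 to compound 4. Compound 4 is therefore estimated at 12000 nM in this assay, with a range from 3000 nM to 50000 nM, and a fair chance that only a limit is again reported.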

Compound 4, half-maximal inhibitory concentration: 8500 nM
Estimate against measurement, compound 4: 1.4-fold (0.15 log units) above, within the range that was stated.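

Notes on the ring swap, compound 4

Within the data shown here, on the aromatic carbon para to the (4-aminocyclohexyl)amino group, replacing piperidin-1-yl with the new six-membered non-aromatic ring with 2 hetero atoms gives the first single value for this substitution pattern: in this assay compound 4 gives 8500 nM. Compound 1 is still held only by a limit, so one end of the comparison is not a number: the limit of > 10000 nM in this assay, at which 1 of the 4 values shown sits.
Read against that limit, the swap gives an at least 1.1-fold lower number from compound 1 to compound 4 (0.07 log units; that floor lies within the scatter), which fixes only a floor for the step, and the full size of the step cannot be read.

Going by these compounds, whether morpholin-4-yl or 4-methylpiperazin-1-yl at the same place, with the (4-fluorobenzyl)carbamoyl group kept, would give a value in this assay remains open. Also open, on these data alone, is whether a smaller ring such as pyrrolidin-1-yl would hold a value there, or whether the piperidin-1-yl entry would resolve into a number at all.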